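The source may report more compounds than this note shows. Statements on the series, on what has been measured and on what is new or still open speak of the compounds shown alone.

In a functional assay on KB cells (Homo sapiens) (on this read-out lower numbers stand for an effect already at smaller amounts and higher numbers for an effect only at larger amounts of compound), compound 1 `Oc1nc(-c2cccc(F)c2)nc2ccccc12` gives 8.5 ug/mL. Compound 2 `Oc1nc(-c2ccc(F)cc2)nc2ccccc12` gives 6.5 ug/mL, and these two values lie within the usual scatter of each other. Compound 3 `COc1cc2nc(-c3cccc(F)c3)nc(O)c2cc1OC` reads > 20 ug/mL, which is a limit of the assay and not a number. Compound 4 `COc1cccc(-c2nc(O)c3ccccc3n2)c1` has not yet been measured and differs from compound 1 in one place: methoxy in place of fluoro on an aromatic carbon. Methoxy stands in place of fluoro on an aromatic carbon, meta to a large group. Among the measured compounds shown here, no measured pair of compounds differs in only one place, so nothing measured sets the size of this step, and no shift beyond the scatter is expected in this assay. The estimated step of a 1.1-fold higher number from compound 1 to compound 4 (0.02 log units; within the scatter) is therefore small. Compound 4 is expected at 9 ug/mL, with an estimated range from 4 ug/mL to 20 ug/mL.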

Compound 4, concentration for half-maximal effect: > 20 ug/mL
Compound 4 was reported as a limit; the forecaster's own chance of this, stated with the estimate: 15%; middle value at least 2.2-fold (0.34 log units) from the limit.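

In this assay, compound 4 reads > 20 ug/mL, which is a limit of the assay and not a number. Among the compounds shown here, this is the first measured change in a single place, and methoxy in place of fluoro gives an at least 2.3-fold higher number from compound 1 to compound 4 (0.37 log units; beyond the scatter), so what sits on this aromatic carbon, meta to a large group, does matter here. The true size of the step stays hidden, and only its lower bound can be read: the limit of > 20 ug/mL in this assay, at which 2 of the 4 values shown sit.

On these data alone, whether chloro, hydroxyl or an amine on this carbon would stay close to compound 1 remains open. So does whether a group larger than methoxy would fare any differently.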